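This account rests on a few compounds, and the source may have more. Where it says the series, first, only, none or still open, it means among the compounds named here.

Within the data shown here, compound 1, whose structure is `Cn1c(-c2ccc(O)cc2)nc2c(NC3CCCC3)ncnc21`, stands as the only compound with a full number in a functional assay on CHO cells for antagonist activity at adenosine receptor A2b (Homo sapiens), read by 33P incorporation, with a stated time of 20 min (on this read-out lower numbers stand for stronger inhibition and higher numbers for weaker inhibition), where compound 1 gives 17800 nM. Compound 2, with structure `Cn1c(-c2ccc(C(=O)O)cc2)nc2c(NC3CCCC3)ncnc21`, returns only a limit in this assay, > 30000 nM, which is the upper limit of the assay and not a number; this is the case of the limit of > 30000 nM in this assay, at which 1 of the 2 values shown sits. Among the measured compounds shown here, the single measured step, an at least 1.6-fold higher number from compound 1 to compound 2 (0.22 log units; that floor lies within the scatter), shows that carboxy in place of hydroxy on an aromatic carbon does not lower the number and may raise it.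

Compound 3, with structure `Cc1cccc(-c2nc3c(NC4CCCC4)ncnc3n2C)c1`, differs from compound 1 as follows: 3-methylphenyl in place of 4-hydroxyphenyl on an aromatic carbon. For the measured compounds named here, no measured step shows this exact change, and the one step available concerns a different replacement at the same aromatic carbon, so it bears on compound 3 only loosely. With compound 1 already near the top of the range and the lone step pointing weaker, the expected step in this assay is a 1.2-fold higher number from compound 1 to compound 3 (0.09 log units; within the scatter), a size that stays within the scatter. Compound 3 is therefore estimated at 22000 nM, with a range from 8000 nM to 60000 nM.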

Compound 3, inhibition constant: 6030 nM
Compound 3: middle estimate off by 3.6-fold (0.56 log units), on the high side, and the stated range ends above it.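

In this assay, replacing 4-hydroxyphenyl with 3-methylphenyl on the aromatic carbon between two ring nitrogen atoms gives a 3.0-fold lower number from compound 1 to compound 3 (0.47 log units; beyond the scatter). This shows that a change at this position can lower the number by more than the scatter, which the earlier step, with its floor within the scatter, could not show. The hydroxy group of compound 1 is also not required for a number at this level, since compound 3 has no hydrogen-bond donor or acceptor on this group and still gives the lower number, though the substituent and its place on the phenyl ring change together, so this single step cannot separate the two.

As far as these compounds go, whether a methyl group kept in the place of the hydroxy group, or an amine or a methoxy group on the phenyl ring, would lower the number further remains open. Compound 2 gives only a limit of the assay and not a number, so how far it lies from the other compounds remains open too: the limit of > 30000 nM in this assay, at which 1 of the 3 values shown sits.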